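The source may hold more compounds than are shown below. What is called first, only, known or untested is meant among the compounds shown, and "the series" means these compounds.

Measured so far:
- compound 1 `CCCCc1cn(C[C@H](O)[C@H]2OC(=O)C(OCc3ccccc3)=C2OCc2ccccc2)nn1`: 26300 nM
- compound 2 `CC(C)(C)c1cn(C[C@H](O)[C@H]2OC(=O)C(OCc3ccccc3)=C2OCc2ccccc2)nn1`: 13300 nM

Both compounds share one core and differ only in the group on an aromatic carbon of the triazole-type five-membered ring. In an ADME assay on HFF cells (Homo sapiens) for cytotoxicity, read by MTT assay, with a stated time of 72 h (a higher number here means a weaker inhibitor, a lower number a stronger inhibitor), compound 1 gives 26300 nM, and compound 2 gives 13300 nM. Within the data shown here, the only change measured so far is a 2.0-fold lower number from compound 1 to compound 2 (0.30 log units; within the scatter), so the two numbers cannot be told apart, and compound 2 stands alongside compound 1 rather than apart from it.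

Compound 3 `COc1ccc(-c2cn(C[C@H](O)[C@H]3OC(=O)C(OCc4ccccc4)=C3OCc3ccccc3)nn2)cc1` carries a larger change at the same place: 4-methoxyphenyl in place of tert-butyl on an aromatic carbon. Among the measured compounds shown here, no measured step here swaps an alkyl group for an aromatic ring, so the only guide is that the one step taken at this position stayed within the scatter. The expectation for compound 3 is therefore a step of a 1.1-fold lower number from compound 2 to compound 3 (0.04 log units; within the scatter), with wide uncertainty. Compound 3 is estimated at 12000 nM, expected to lie between 4000 nM and 40000 nM.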

Compound 3, half-maximal inhibitory concentration: < 10 nM
Compound 3: only a limit was reported; the forecaster's own chance of this, stated with the estimate: 15%; middle value at least 1200-fold (3.07 log units) from the limit.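

In this assay, this position turns out to be far from indifferent to what it carries: putting 4-methoxyphenyl in place of an alkyl group gives an at least 1300-fold lower number from compound 2 to compound 3 (3.12 log units; beyond the scatter) and an at least 2600-fold lower number from compound 1 to compound 3 (3.41 log units; beyond the scatter). Exchanging one alkyl group for another had shown only a 2.0-fold lower number from compound 1 to compound 2 (0.30 log units; within the scatter), so the earlier pair gave no sign that a change here could matter this much. The number for compound 3 is a limit of the assay and not a measured value, so both large steps are minimum sizes: the limit of < 10 nM in this assay, at which 1 of the 3 values shown sits.

The compounds shown cannot separate the effect of the aromatic ring from that of its methoxy group; plain phenyl, or a phenyl ring carrying an amine or a carboxylic acid instead of methoxy, would address this. Going by these compounds, how much lower the true number for compound 3 lies also remains open.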